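The source may report more compounds than this note shows. Statements on the series, on what has been measured and on what is new or still open speak of the compounds shown alone.

Compound 1 `CC(C)C(c1ncco1)c1ccc(-c2ccc3cccc(F)c3c2)[nH]c1=O`: 0.178 h
Compound 2 `Cc1nc(C(c2ccc(-c3ccc4cccc(F)c4c3)[nH]c2=O)C(C)C)[nH]c1C`: 0.268 h
Compound 3 `CC(C)C(Cc1nnn[nH]1)c1ccc(-c2ccc3cccc(F)c3c2)[nH]c1=O`: > 3 h

All three share one core and were tested in an ADME assay on microsomes from liver (Homo sapiens) for metabolic stability; a higher number here means that the compound lasts longer, a lower number that the compound disappears faster. Of the two plain numbers, compound 1 stands lowest; the nearest is compound 2, and the step of a 1.5-fold higher number from compound 1 to compound 2 (0.18 log units; within the scatter) lies within the scatter, so no order can be read between them. For compound 3 the result is not a number but a limit of the assay (the limit of > 3 h in this assay, at which 1 of the 3 values shown sits).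

Compound 4 `CC(C)C(/C=C1\CCNC1=O)c1ccc(-c2ccc3cccc(F)c3c2)[nH]c1=O` differs from compound 1 in one place: a group of 7 heavy atoms (5 carbon, 1 nitrogen, 1 oxygen; one five-membered non-aromatic ring with 1 hetero atom) in place of a group of 5 heavy atoms (3 carbon, 1 nitrogen, 1 oxygen; one five-membered aromatic ring with 2 hetero atoms), on a saturated chain carbon bound to an aromatic carbon and a saturated chain carbon. Two measured steps leave the same 1,3-oxazol-2-yl group at the same place. Putting 4,5-dimethyl-1H-imidazol-2-yl there gave a 1.5-fold higher number from compound 1 to compound 2 (0.18 log units; within the scatter), while putting (1H-tetrazol-5-yl)methyl there gave an at least 16-fold higher number from compound 1 to compound 3 (1.22 log units; beyond the scatter), a large gain. The group entering compound 4 is neither of these, so the evidence points in a direction without fixing the size.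

A moderate rise is expected. Compound 4 is estimated to give 0.35 h, within 0.12 h to 1.2 h, which means an expected step of a 2.0-fold higher number from compound 1 to compound 4 (0.29 log units; within the scatter).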

Compound 4, half-life: 0.713 h
Compound 4: middle estimate off by 2.0-fold (0.31 log units), on the low side; measured number inside the range.
By their numbers in this assay, from the lowest: compounds 1 and 2 (each within the scatter of the next); then compound 4. At a limit, above all of these: compound 3.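

In this assay, going by these compounds alone, the earlier compounds showed a gain beyond the scatter at this saturated chain carbon only with (1H-tetrazol-5-yl)methyl, and the non-aromatic five-membered ring of compound 4 now provides a second case: a 4.0-fold higher number from compound 1 to compound 4 (0.60 log units; beyond the scatter), and a 2.7-fold higher number from compound 2 to compound 4 (0.42 log units; beyond the scatter). That gain still falls short of the tetrazole group: an at least 4.2-fold lower number from compound 3 to compound 4 (0.62 log units; beyond the scatter). The result for compound 3 is a limit and not a number: the limit of > 3 h in this assay, at which 1 of the 4 values shown sits.

The compounds shown do not tell whether the gain in compound 4 comes from the ring itself, from a double bond outside aromatic rings, or from its hydrogen-bond donor. A carboxylic acid or an amine on this carbon, or the same ring joined through a saturated chain, would help separate these possibilities.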